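The compounds below may be only part of what the source reports. "The series", "measured", "known", "first", "only" and "open" are said of these compounds alone.

In a functional assay on HepG2 cells (Homo sapiens) for cytotoxicity, read by MTT assay, with a stated time of 24 h (on this read-out higher numbers stand for weaker inhibition and lower numbers for stronger inhibition), compound 1 (`Cc1ccc(S(=O)(=O)N2C/C(=C\c3cccnc3)C(=O)/C(=C/c3ccccc3F)C2)cc1`) reads 4200 nM and compound 2 (`O=C1/C(=C/c2ccncc2)CNC/C1=C\c1ccccc1F`) reads 8200 nM. Compound 3 (`O=C1/C(=C/c2ccncc2)CN(S(=O)(=O)c2ccccc2)C/C1=C\c1ccccc1F`) reads 5800 nM and lies within the scatter of both others, so the three values set no order. Compound 4 (`Cc1ccc(S(=O)(=O)N2C/C(=C\c3ccncc3)C(=O)/C(=C/c3ccccc3F)C2)cc1`) differs from compound 3 by methyl in place of hydrogen on an aromatic carbon, para to a large group (methyl in place of hydrogen on an aromatic carbon), taking phenylsulfonyl to (4-methylphenyl)sulfonyl. Among the measured compounds shown here, one measured step bears on this (a 1.4-fold lower number from compound 2 to compound 3 (0.15 log units; within the scatter)): adding the whole phenylsulfonyl group stayed within the scatter. A change beyond the scatter in this assay is therefore not expected, and no direction can be called with confidence. The estimated step (a 1.2-fold lower number from compound 3 to compound 4 (0.06 log units; within the scatter)) is expected to stay within the scatter. Compound 4 is estimated at 5000 nM (expected range 2600 nM to 9500 nM).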

Compound 4, half-maximal inhibitory concentration: 9700 nM
For compound 4 the middle estimate is 1.9-fold (0.29 log units) below the measured one; measured number outside the range, above it.
By their numbers in this assay, from the lowest: compounds 1, 3, 2 and 4 (each within the scatter of the next, the first and the last beyond it).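

In this assay, methyl on the phenyl ring, phenyl to 4-methylphenyl, stays within the scatter (a 1.7-fold higher number from compound 3 to compound 4 (0.22 log units; within the scatter)), as does the whole (4-methylphenyl)sulfonyl group on the amine nitrogen in the ring (a 1.2-fold higher number from compound 2 to compound 4 (0.07 log units; within the scatter)). Among the compounds shown here, the only step beyond the scatter is at the other site, where pyridin-4-yl replaces pyridin-3-yl (a 2.3-fold higher number from compound 1 to compound 4 (0.36 log units; beyond the scatter)), though it is modest and rests on a single pair. Open, as far as these compounds go, is whether an amine or a carboxylic acid in place of that methyl would move the number beyond the scatter. No measurement shown accounts for the pyridine step.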